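This account rests on a few compounds, and the source may have more. Where it says the series, first, only, none or still open, it means among the compounds named here.

Working notes on the series in a functional assay on NCI/ADR-RES cells (Homo sapiens) for inhibition, read by sulforhodamine B assay, with a stated time of 48 h; on this read-out higher numbers stand for weaker inhibition of growth and lower numbers for stronger inhibition of growth. Compound 2 (`COc1ccc(/C=C/C2(C)C=CC(=O)O2)c(OC)c1`) gives 151000 nM and compound 3 (`COc1cc(OC)c(/C=C/C2(C)C=CC(=O)O2)c(OC)c1`) gives 229000 nM, so these two stand together within the scatter. Compound 1 (`CC1(/C=C/c2ccccc2)C=CC(=O)O1`) gives 414000 nM, a higher number than compound 2 shows, which places compound 2 at the low end of the three alongside compound 3.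

Compound 4 (`COc1ccccc1/C=C/C1(C)C=CC(=O)O1`) follows from compound 2 by hydrogen in place of methoxy on an aromatic carbon. Within the data shown here, the only measured step in one place, a 1.5-fold higher number from compound 2 to compound 3 (0.18 log units; within the scatter), also concerns a methoxy on an aromatic carbon, and it runs the opposite way, with methoxy entering. Compound 1, at 414000 nM, carries hydrogen in place of every methoxy of compound 2. A small move towards a higher number in this assay is therefore expected, and no large one. The expected step is a 1.5-fold higher number from compound 2 to compound 4 (0.18 log units; within the scatter). For compound 4 the estimate is 230000 nM, with an expected range of 120000 nM to 430000 nM.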

Compound 4, concentration for total growth inhibition: 64500 nM
The estimate for compound 4 lay 3.6-fold (0.55 log units) above the measured number; the measured number lies below the stated range.
By their numbers in this assay, from the lowest: compound 4; then compounds 2, 3 and 1 (each within the scatter of the next, the first and the last beyond it).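

In this assay, hydrogen in place of methoxy on the aromatic carbon para to a group of 9 heavy atoms gives a 2.3-fold lower number from compound 2 to compound 4 (0.37 log units; beyond the scatter), so at this place the methoxy of compound 2 is not needed for the lower number. The remaining methoxy of compound 4 counts as a gain over the unsubstituted core, with a 6.4-fold lower number from compound 1 to compound 4 (0.81 log units; beyond the scatter), so adding methoxy does not move the read-out in a single direction across the series. The change does not carry over from one core to another: the same change on two cores in this assay, a 1.5-fold higher number (0.18 log units; within the scatter) from compound 2 to compound 3 and a 6.4-fold lower number (0.81 log units; beyond the scatter) from compound 1 to compound 4, 9.7-fold (0.99 log units) apart, beyond the scatter of two such steps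

Still open, on these data alone, is how the core of compound 1 would read with a single methoxy on the aromatic carbon para to the group of 9 heavy atoms. As far as these compounds go, it is also open whether a hydroxyl, a fluorine or an ethoxy at this place would read like hydrogen or like methoxy.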